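The source may hold more compounds than are shown below. What is called first, only, known or untested is meant among the compounds shown, and "the series" means these compounds.

Compounds measured so far in an in vitro assay on 293-EBNA cells for binding affinity to corticotropin-releasing factor receptor 1 (Homo sapiens); on this read-out lower numbers stand for stronger inhibition and higher numbers for weaker inhibition:

compound 1, `CCCCN(CC)c1nc(C)nc2c1nnn2-c1ccc(C(C)C)cc1Br`: 7.5 nM
compound 2, `COCCCNc1nc(C)nc2c1nnn2-c1ccc(C(C)C)cc1Br`: 291 nM
compound 3, `CCC(COC)Nc1nc(C)nc2c1nnn2-c1ccc(C(C)C)cc1Br`: 7.5 nM; 6.1 nM; 9.4 nM (3 entries)

Compound 2 stands at the highest of the two single numbers in this assay. For the measured compounds named here, its nearest neighbour is compound 1, and the one measured step is a 39-fold higher number from compound 1 to compound 2 (1.59 log units; beyond the scatter), a change in which a (3-methoxypropyl)amino takes the place of butyl(ethyl)amino on an aromatic carbon. Compound 3 has repeated entries in this assay, (the several entries of compound 3 in this assay, 7.5 nM; 6.1 nM; 9.4 nM (3 entries)), and they lie close to one another; they sit near the number for compound 1 rather than near that for compound 2.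

Compound 4, `CCOCC(COCC)Oc1nc(C)nc2c1nnn2-c1ccc(C(C)C)cc1Br`, differs from compound 2 by a group of 10 heavy atoms (7 carbon, 3 oxygen; no ring) in place of a group of 6 heavy atoms (4 carbon, 1 nitrogen, 1 oxygen; no ring), on an aromatic carbon. Going by the values given here, no measured step covers an exchange of this kind, in which the amino link gives way to an oxygen link and a branched, doubly ethoxylated chain enters. Among the compounds with values here, the only guidance is that the single, straight methoxy-bearing chain of compound 2 gave the weakest number, while the branched chain of compound 3 did not. On that basis the step in this assay is expected to be a 4.9-fold lower number from compound 2 to compound 4 (0.69 log units; beyond the scatter), with wide uncertainty. Compound 4 is therefore estimated at 60 nM, within a range from 10 nM to 400 nM.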

Compound 4, inhibition constant: 39.7 nM
For compound 4 the middle estimate is 1.5-fold (0.18 log units) above the measured one; the range from low to high includes it.
By their numbers in this assay, from the lowest: compound 1; then compound 4; then compound 2.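

The place on the aromatic carbon next to the ring nitrogen does not depend on a nitrogen link for a fairly low number: in this assay, swapping (3-methoxypropyl)amino, which has 1 hydrogen-bond donor, for an oxygen-linked branched chain with 0 hydrogen-bond donors gives a 7.3-fold lower number from compound 2 to compound 4 (0.87 log units; beyond the scatter). This oxygen-linked group still does not match butyl(ethyl)amino, with a 5.3-fold higher number from compound 1 to compound 4 (0.72 log units; beyond the scatter), so the two lowest results so far both belong to nitrogen-linked groups. Compound 4, at 39.7 nM, also lies above every value for the branched nitrogen-linked chain of compound 3, whose repeats agree closely enough to make that gap easy to read: the several entries of compound 3 in this assay, 7.5 nM; 6.1 nM; 9.4 nM (3 entries)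

Compound 4 changes the link and the chain together, so the compounds shown cannot separate what the oxygen contributes from what the two ethoxy arms contribute. An amine carrying the same branched diethoxy chain, or an ether carrying the shorter methoxy-bearing branched chain of compound 3, would pull those two changes apart.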